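Methoxy added to the aniline of compound 2

The source may hold more compounds than are shown below. What is called first, only, known or untested is meant among the compounds shown, and "the series" means these compounds.

Compound 1 `CN1CCN(Cc2ccc(Nc3nc(Oc4ccc5ccc(=O)[nH]c5c4)c4sccc4n3)cc2)CC1` gives 19300 nM in a functional assay on PC-9 cells (Homo sapiens) for antiproliferative activity, read by MTT assay, with a stated time of 72 h; on this read-out lower numbers stand for stronger inhibition and higher numbers for weaker inhibition.
Compound 2 `CN1CCN(c2ccc(Nc3nc(Oc4ccc5ccc(=O)[nH]c5c4)c4sccc4n3)cc2)CC1` gives 5780 nM in this assay.
Compound 3 `CCN1CCN(Cc2ccc(Nc3nc(Oc4ccc5ccc(=O)[nH]c5c4)c4sccc4n3)cc2)CC1` gives 17500 nM in this assay.

Among the three measured compounds, compound 2 holds the lowest number in this assay; the step of a 3.3-fold lower number from compound 1 to compound 2 (0.52 log units; beyond the scatter) and the step of a 3.0-fold higher number from compound 2 to compound 3 (0.48 log units; beyond the scatter) both lie beyond the scatter, so compound 2 stands apart from the other two. The step of a 1.1-fold lower number from compound 1 to compound 3 (0.04 log units; within the scatter) lies within the scatter.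

Compound 4 `COc1cc(N2CCN(C)CC2)ccc1Nc1nc(Oc2ccc3ccc(=O)[nH]c3c2)c2sccc2n1` has not yet been measured. It differs from compound 2 by methoxy in place of hydrogen on an aromatic carbon. Going by the values given here, none of the measured steps concerns such a change: the measured steps vary the piperazine part and its link to the ring, not a substituent on the aniline ring. There is therefore no direct guide for the size or direction of this change. On that basis the step of a 1.4-fold lower number from compound 2 to compound 4 (0.16 log units; within the scatter) is expected as an estimate, with wide uncertainty. Compound 4 is estimated at 4000 nM in this assay, with a range from 1200 nM to 13000 nM.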

Compound 4, half-maximal inhibitory concentration: 22100 nM
Compound 4: the middle estimate sits 5.5-fold (0.74 log units) below what was measured, and the stated range ends below it.
By their numbers in this assay, from the lowest: compound 2; then compounds 3, 1 and 4 (each within the scatter of the next).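

In this assay, methoxy in place of hydrogen on the aromatic carbon ortho to a large group and meta to the 4-methylpiperazin-1-yl group gives a 3.8-fold higher number from compound 2 to compound 4 (0.58 log units; beyond the scatter) and so moves the number towards weaker inhibition. The earlier steps shown here varied only the piperazine part and its link to the ring, whereas this one shows that a change on the aniline ring itself, of only 2 heavy atoms, can also carry the number beyond the scatter. Nothing available explains this loss.

The compounds shown leave open whether fluorine or methyl on this carbon would shift the number as methoxy does, and whether methoxy on another carbon of this ring would do the same. They also leave open whether methoxy has the same effect alongside the (4-methylpiperazin-1-yl)methyl group of compound 1.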